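The compounds below may be only part of what the source reports. "The series", "measured", "known", "first", "only" and "open" are said of these compounds alone.

Compound 1 `COc1ccccc1NC(=O)NC1CC(C)(C)Oc2ccc(F)cc21` sits at a limit in a functional assay (aorta) with Rattus norvegicus as the target; on this read-out higher numbers stand for an effect only at larger amounts of compound and lower numbers for an effect already at smaller amounts: in this assay compound 1 gives > 10000 nM, a limit of the assay rather than a number. Compound 2 `Cc1ccccc1NC(=O)NC1CC(C)(C)Oc2ccc(F)cc21` likewise reaches only a limit, giving > 30000 nM in this assay. Compound 3 `Cc1cccc(NC(=O)NC2CC(C)(C)Oc3ccc(F)cc32)c1` stands at a limit as well, giving > 30000 nM in this assay. The steps a step that the two limits leave unreadable from compound 1 to compound 2, a step that the two limits leave unreadable from compound 1 to compound 3 and a step that the two limits leave unreadable from compound 2 to compound 3 have no readable size because the limit of > 10000 nM in this assay, at which 1 of the 3 values shown sits, and the limit of > 30000 nM in this assay, at which 2 of the 3 values shown sit, hold every value shown. Compound 4 `CC1(C)CC(NC(=O)Nc2cccc(Cl)c2)c2cc(F)ccc2O1` differs from compound 3 by chloro in place of methyl on an aromatic carbon. Going by the values given here, no measured step gives a size for such a change, so no effect beyond the scatter is expected. Compound 4 is expected to give 40000 nM in this assay, within 15000 nM to 100000 nM. The step that the limit leaves unreadable from compound 3 to compound 4 is expected to stay within the scatter.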

Compound 4, half-maximal effective concentration: > 300000 nM
Compound 4: a limit, no number; the forecaster's own chance of this, stated with the estimate: 85%; middle value at least 7.5-fold (0.87 log units) away from the limit.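

Compound 4 stands at a limit in this assay, as do compound 1, compound 2 and compound 3, so no step among these four compounds can be read. The compounds shown leave open whether exchanging methoxy, methyl or chloro on the aromatic ring changes the effect in this assay at all.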